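Notes on the step from compound 2 to compound 4

The compounds below may be only part of what the source reports. "The series", "measured", "known", "first", "only" and "open" are said of these compounds alone.

In this series only compound 2 `O=C(Nc1cc2cc[nH]c(=O)c2cc1Cl)[C@@H]1CCCNC1` carries a number. In a functional assay on aorta (Rattus norvegicus) for inhibition (a higher number here means a weaker inhibitor, a lower number a stronger inhibitor), compound 2 gives 550 nM as the sole measured result. For compound 1 `CC(C)c1cccc(C2CNCC2C(=O)Nc2cc3cc[nH]c(=O)c3cc2Cl)c1` the entry reads "not determined" (no result reported). For compound 3 `Cc1cccc(C2CNCC2C(=O)Nc2cc3cc[nH]c(=O)c3cc2Cl)c1` the entry reads "not determined" (no result reported). Compound 2 therefore cannot be ranked against anything and serves only as the reference point.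

Compound 4 `CN1CCC(C(=O)Nc2cc3cc[nH]c(=O)c3cc2Cl)CC1` awaits measurement. It keeps the shared core of compound 2 and differs at one place, with 1-methylpiperidin-4-yl in place of piperidin-3-yl on a carbonyl carbon as the whole of the change.

For the measured compounds named here, no measured pair shows the size of such a change, so the expectation rests on the structural difference alone and is loose. Somewhat weaker inhibition in this assay is expected, though a result within the usual scatter of compound 2 would not be surprising. The expected step is a 2.7-fold higher number from compound 2 to compound 4 (0.44 log units; beyond the scatter) by this estimate. For compound 4 the estimated half-maximal inhibitory concentration is 1500 nM with an expected range from 400 nM to 6000 nM in this read-out.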

Compound 4, half-maximal inhibitory concentration: 250 nM
The estimate for compound 4 lay 6.0-fold (0.78 log units) above the measured number; measured number below the stated range.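

In this assay, for the compounds shown here, 1-methylpiperidin-4-yl in place of piperidin-3-yl on a carbonyl carbon gives a 2.2-fold lower number from compound 2 to compound 4 (0.34 log units; beyond the scatter), the first measured step, and it shows that this position accepts a change of the whole group without loss of inhibition. Going by these compounds alone, the entering group has no defined stereocentre and no hydrogen-bond donor, whereas the leaving group has both, so neither feature is needed for a number at this level in this pair, although the single step cannot separate their contributions. Nothing available bears on why the number falls.

Steps to compound 1 and compound 3 cannot be read, as neither has a number. Plain piperidin-4-yl and 1-ethylpiperidin-4-yl would help separate the contribution of the methyl from that of the change from piperidin-3-yl to piperidin-4-yl, which remains open here.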